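A Urea Tail Swap on a Shared Core

This account rests on a few compounds, and the source may have more. Where it says the series, first, only, none or still open, it means among the compounds named here.

compound 1 `COc1ncc(-c2ccc3nc(NC(=O)NCC(=O)N4CCCCC4)nn3c2)cc1NS(=O)(=O)c1ccc(F)cc1` — 570 nM
compound 2 `COc1ncc(-c2ccc3nc(NC(=O)NCCN(C)C)nn3c2)cc1NS(=O)(=O)c1ccc(F)cc1` — 560 nM
compound 3 `COc1ncc(-c2ccc3nc(NC(=O)NCC(=O)N4CCOCC4)nn3c2)cc1NS(=O)(=O)c1ccc(F)cc1` — 630 nM

All three were tested in a functional assay on MCF7 cells (Homo sapiens) for cytotoxicity, read by MTT assay, with a stated time of 72 h; a lower number here means a stronger inhibitor, a higher number a weaker inhibitor. Compound 1 holds the second highest of the three numbers, with a 1.0-fold lower number from compound 1 to compound 2 (0.01 log units; within the scatter) and a 1.1-fold higher number from compound 1 to compound 3 (0.04 log units; within the scatter), so the three compounds stand within the scatter of one another. Compound 4 `COc1ncc(-c2ccc3nc(NC(=O)NCCN4CCN(C)CC4)nn3c2)cc1NS(=O)(=O)c1ccc(F)cc1` is not yet measured; it differs from compound 1 by (4-methylpiperazin-1-yl)methyl in place of (piperidin-1-yl)carbonyl on a saturated chain carbon bound to an amide-type nitrogen. The closest guide is the change from compound 1 to compound 2, which also replaced the (piperidin-1-yl)carbonyl with a nitrogen-bearing group and gave no step beyond the scatter. Compound 4 is therefore expected near 580 nM, with a range from 290 nM to 1200 nM. That amounts to an expected 1.0-fold higher number from compound 1 to compound 4 (0.01 log units; within the scatter), no real movement beyond the scatter.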

Compound 4, half-maximal inhibitory concentration: 500 nM
The estimate for compound 4 lay 1.2-fold (0.06 log units) above the measured number; the measured number falls inside the stated range.
By their numbers in this assay, from the lowest: compounds 4, 2, 1 and 3 (each within the scatter of the next).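

In this assay, the tail on the saturated chain carbon bound to an amide-type nitrogen accepted (4-methylpiperazin-1-yl)methyl with no step beyond the scatter: a 1.1-fold lower number from compound 1 to compound 4 (0.06 log units; within the scatter), a 1.3-fold lower number from compound 3 to compound 4 (0.10 log units; within the scatter) and a 1.1-fold lower number from compound 2 to compound 4 (0.05 log units; within the scatter). With this change, 4-methylpiperazin-1-yl joins dimethylamino, and all four tails on the shared core stand within the scatter of one another. No measurement shown accounts for this flat result. Going by these compounds, whether a carboxylic acid or a longer chain at this place would give a step beyond the scatter remains open.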